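The source may report more compounds than this note shows. Statements on the series, on what has been measured and on what is new or still open speak of the compounds shown alone.

Compound 2 `CNc1nc(-n2cc(CC3CCCC3)nn2)nc2c1ncn2[C@@H]1O[C@H](CO)[C@@H](O)[C@H]1O` gives 1.3 nM in an assay on CHO cells for displacement of a labelled ligand from adenosine receptor A3 (Homo sapiens) (on this read-out lower numbers stand for stronger inhibition and higher numbers for weaker inhibition), the lowest of the two numbers in hand; compound 1 `CNc1nc(-n2cc(-c3ccccc3)nn2)nc2c1ncn2[C@@H]1O[C@H](CO)[C@@H](O)[C@H]1O` gives 14.9 nM in this assay. Among the measured compounds shown here, the one measured step, an 11-fold lower number from compound 1 to compound 2 (1.06 log units; beyond the scatter), shows that a saturated ring at this position is well tolerated. Compound 3 `CNc1nc(-n2cc(CC3CCCCC3)nn2)nc2c1ncn2[C@@H]1O[C@H](CO)[C@@H](O)[C@H]1O` carries cyclohexyl in place of cyclopentyl on a saturated chain carbon bound to an aromatic carbon. For the measured compounds named here, no measured step addresses ring size within the saturated series, so the change is expected to stay within the scatter: the step from compound 2 to compound 3 is estimated as a 1.2-fold higher number from compound 2 to compound 3 (0.06 log units; within the scatter). Compound 3 is expected to give 1.5 nM in this assay, in the range 0.5 nM to 5 nM.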

Compound 3, inhibition constant: 21.3 nM
The estimate for compound 3 lay 14-fold (1.15 log units) below the measured number; the whole stated range lies below it.
By their numbers in this assay, from the lowest: compound 2; then compounds 1 and 3 (each within the scatter of the next).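

Ring size on this saturated chain carbon matters in this assay: cyclohexyl in place of cyclopentyl gives a 16-fold higher number from compound 2 to compound 3 (1.21 log units; beyond the scatter) and removes the advantage held by compound 2. Cyclohexylmethyl in place of phenyl gives a 1.4-fold higher number from compound 1 to compound 3 (0.16 log units; within the scatter) and so a saturated ring alone does not secure the low number of compound 2. No evidence in hand accounts for the difference between the two rings. On these data alone, it remains open whether cyclobutylmethyl, or a nitrogen-containing ring such as piperidinylmethyl, would match cyclopentylmethyl.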